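The source may hold more compounds than are shown below. What is called first, only, known or untested is meant among the compounds shown, and "the series" means these compounds.

Measured compounds:
compound 1 `CN(C(=O)C[C@@H](N)CCCCN)C1CN=C(Nc2ncccn2)NC1=O`: 380 nM
compound 2 `CN(C(=O)C[C@@H](N)CCCCN)C1CN=C(Nc2ccc3ccccc3n2)NC1=O`: 50 nM
compound 3 `CN(C(=O)C[C@@H](N)CCCCN)C1CN=C(Nc2cnccn2)NC1=O`: < 100 nM

In a functional assay for inhibition, with Oryctolagus cuniculus as the target (a higher number here means a weaker inhibitor, a lower number a stronger inhibitor), compound 2 gives the lowest of the two numbers shown; the nearest is compound 1, a step of a 7.6-fold lower number from compound 1 to compound 2 (0.88 log units; beyond the scatter). For compound 3 the value in this assay is a limit of the assay, not a number (the limit of < 100 nM in this assay, at which 1 of the 3 values shown sits). Compound 4 `CN(C(=O)C[C@@H](N)CCCN=C(N)N)C1CN=C(Nc2ccc3ccccc3n2)NC1=O` differs from compound 2 in a group of 4 heavy atoms (1 carbon, 3 nitrogen; no ring) in place of a group of 2 heavy atoms (1 carbon, 1 nitrogen; no ring), on a saturated chain carbon, four bonds along the chain from an amine nitrogen. The measured steps all alter the group on the amine nitrogen (an at least 3.8-fold lower number from compound 1 to compound 3 (0.57 log units; beyond the scatter), a step that the limit leaves unreadable from compound 2 to compound 3), so none bears on a change on the chain. No step beyond the scatter is therefore expected in this assay for compound 4, in either direction; the expected step is no change at the digits printed from compound 2 to compound 4 (within the scatter). Compound 4 is estimated at 50 nM, within 15 nM to 200 nM.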

Compound 4, half-maximal inhibitory concentration: 100 nM
Estimate against measurement, compound 4: 2.0-fold (0.30 log units) below; the range from low to high includes it.
By their numbers in this assay, from the lowest: compounds 2 and 4 (each within the scatter of the next); then compound 1.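

Earlier steps all altered the group on the amine nitrogen; this one reads a change on the chain, giving in this assay a 2.0-fold higher number from compound 2 to compound 4 (0.30 log units; within the scatter) with the quinolin-2-yl group held. At this chain position, the group of 4 heavy atoms can therefore replace aminomethyl with no change beyond the scatter. Nothing here gives a reason for this step. Still open, as far as these compounds go, is whether a carboxylic acid or a simple amide at the chain end, or a shorter or longer chain, keeps the number. Also open, from the compounds shown here alone, is whether the same change gives a similar step with pyrimidin-2-yl or pyrazin-2-yl on the amine nitrogen.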